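Methylsulfanyl for methoxy on the aryl hydrazone of the core

The source may report more compounds than this note shows. Statements on the series, on what has been measured and on what is new or still open speak of the compounds shown alone.

For the measured compounds named here, compound 1 `COc1cccc(/C=N/Nc2ncc3c(n2)n(C2CCCC2)c(=O)c(=O)n3C)c1` is the only member of the series with a measured number rather than a limit. In a functional assay on A549 cells (Homo sapiens) for antiproliferative activity, read by MTT assay (a lower number here means a stronger inhibitor, a higher number a weaker inhibitor), compound 1 gives 27400 nM. Compound 2 `COc1ccc(/C=N/Nc2ncc3c(n2)n(C2CCCC2)c(=O)c(=O)n3C)c(OC)c1` reaches only a limit of the assay, and in this assay compound 2 gives > 100000 nM. Going by the values given here, the single measured step is therefore an at least 3.6-fold higher number from compound 1 to compound 2 (0.56 log units; beyond the scatter), known only as a bound because of the limit of > 100000 nM in this assay, at which 1 of the 2 values shown sits.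

Compound 3 `CSc1ccc(/C=N/Nc2ncc3c(n2)n(C2CCCC2)c(=O)c(=O)n3C)cc1` differs from compound 1 by 4-(methylsulfanyl)phenyl in place of 3-methoxyphenyl on a carbon with a double bond to nitrogen. Among the compounds with values here, no measured step carries this particular change; the step from compound 1 to compound 2 alters the aryl group in a different way and cannot be read as a guide to direction here. With compound 1 already weak and one of the two values at the limit of this assay, the expectation for compound 3 is a number near that of compound 1, with a wide range leaning toward the weaker side, that is an expected step of a 1.5-fold higher number from compound 1 to compound 3 (0.16 log units; within the scatter). In this assay compound 3 is estimated at 40000 nM, within a range from 12000 nM to 150000 nM, and a further limit reading would not be surprising.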

Compound 3, half-maximal inhibitory concentration: 14100 nM
Estimate against measurement, compound 3: 2.8-fold (0.45 log units) above; low and high end bracket the measured number.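

In this assay the group on a carbon with a double bond to nitrogen can be 4-(methylsulfanyl)phenyl instead of 3-methoxyphenyl without a readable change, with (a 1.9-fold lower number from compound 1 to compound 3 (0.29 log units; within the scatter)) as the step, so the series now holds two measured numbers that lie within the scatter of each other. The loss seen with 2,4-dimethoxyphenyl is therefore not shared by every replacement at this place: replacing that group gives (an at least 7.0-fold lower number from compound 2 to compound 3 (0.85 log units; beyond the scatter)) as the step, and its size is known only as a bound. That bound rests on an assay limit and not on a number: the limit of > 100000 nM in this assay, at which 1 of the 3 values shown sits.

Compound 1 and compound 3 differ in both the linking atom and the ring position in the group names, and the compounds shown do not separate the two, as neither 4-methoxyphenyl nor 3-(methylsulfanyl)phenyl is among them. Also open, as far as these compounds go, is how this place responds to a longer chain on the sulfur, such as ethylsulfanyl, or to an amine or a carboxylic acid on the aromatic ring, and whether any of these gives a number clearly lower than those of compound 1 and compound 3.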